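A few compounds are considered here, and "the series" means these few. Any claim that something is new, unique, unknown or untested is made for them only; others in the source may bear on it.

Working notes on the series.

Compound 1 `Cc1ccc(-c2csc(NC(=O)COc3ccccc3C)n2)cc1` is the reference point; in a functional assay on Ehrlich cells (Mus musculus) for cytotoxicity, read by MTT assay, with a stated time of 48 h (on this read-out higher numbers stand for weaker inhibition and lower numbers for stronger inhibition), compound 1 gives 54400 nM. Compound 2 `Cc1ccc(-c2csc(NC(=O)COc3ccccc3C(C)C)n2)cc1` differs from it by isopropyl in place of methyl on an aromatic carbon, and in this assay compound 2 gives 42900 nM, which amounts to a 1.3-fold lower number from compound 1 to compound 2 (0.10 log units; within the scatter). Compound 3 `Cc1ccccc1OCC(=O)Nc1nc(-c2ccc(Cl)cc2)cs1` carries the other core; it differs from compound 1 by chloro in place of methyl on an aromatic carbon, and in this assay compound 3 gives 62300 nM, a move of a 1.1-fold higher number from compound 1 to compound 3 (0.06 log units; within the scatter). All three numbers therefore lie close together.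

Compound 4 `CC(C)c1ccccc1OCC(=O)Nc1nc(-c2ccc(Cl)cc2)cs1` is not yet measured. It differs from compound 3 by isopropyl in place of methyl on an aromatic carbon, the same change already seen from compound 1 to compound 2, made on the same kind of place. The two cores differ as described by chloro in place of methyl on an aromatic carbon.

The expected step for compound 4 in this assay is a 1.3-fold lower number from compound 3 to compound 4 (0.11 log units; within the scatter), set beside the earlier one because a 1.3-fold lower number from compound 1 to compound 2 (0.10 log units; within the scatter) was small, and the core change gave no sign of altering that. Compound 4 is therefore estimated at 48000 nM, with a likely range from 25000 nM to 95000 nM.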

Compound 4, half-maximal inhibitory concentration: 50100 nM
Estimate against measurement, compound 4: 1.0-fold (0.02 log units) below; the range from low to high includes it.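

In this assay, isopropyl in place of methyl on an aromatic carbon gives a 1.2-fold lower number from compound 3 to compound 4 (0.09 log units; within the scatter), and this step matches the one seen on the core of compound 1: the same change on two cores in this assay, a 1.3-fold lower number (0.10 log units; within the scatter) from compound 1 to compound 2 and a 1.2-fold lower number (0.09 log units; within the scatter) from compound 3 to compound 4, 1.0-fold (0.01 log units) apart, within the scatter of two such steps. Chloro in place of methyl on an aromatic carbon, read with isopropyl present, gives a 1.2-fold higher number from compound 2 to compound 4 (0.07 log units; within the scatter), and this step also matches its earlier counterpart: the same change on two cores in this assay, a 1.1-fold higher number (0.06 log units; within the scatter) from compound 1 to compound 3 and a 1.2-fold higher number (0.07 log units; within the scatter) from compound 2 to compound 4, 1.0-fold (0.01 log units) apart, within the scatter of two such steps. For the compounds shown here, both changes therefore carry from one core to the other without a detectable difference, but all four steps lie within the scatter, so this shows only that neither change moves the number measurably on these cores, not that a real effect of either change transfers.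

The compounds shown leave open whether a different group at the same place, such as an amine, a carboxylic acid or a longer chain, would give a step beyond the scatter. They also leave open whether such a step would carry between the cores as closely as these small ones do.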